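The source may report more compounds than this note shows. Statements on the series, on what has been measured and on what is new or still open speak of the compounds shown alone.

Measured so far:
- compound 1, `COc1ccc(N(CC(=O)NCCCSc2ccccc2)C(=O)CCSC2=C(C)C(=O)c3ccccc3C2=O)cc1`: 16000 nM
- compound 2, `O=C(COC(=O)/C=C/c1ccccc1)NCCC[Te]c1ccccc1`: 1000 nM

Both numbers come from a functional assay on MCF7 cells (Homo sapiens) for cytotoxicity, read by MTT assay, with a stated time of 24 h; on this read-out higher numbers stand for weaker inhibition and lower numbers for stronger inhibition. Compound 1 stands at the highest of the two numbers; the nearest is compound 2, whose lower number lies beyond the usual scatter, so on this read-out compound 2 is the stronger of the two. The two share only the chain-linked phenyl-chalcogen tail and are otherwise built on different cores, so nothing about the step between them can be assigned to any single change.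

Compound 3, `COc1ccc(N(CC(=O)NCCC[Te]c2ccccc2)C(=O)CCSC2=C(C)C(=O)c3ccccc3C2=O)cc1`, keeps the core of compound 1 and differs from it in one place: a group of 7 heavy atoms (6 carbon, 1 tellurium; one six-membered aromatic ring of carbon only) in place of a group of 7 heavy atoms (6 carbon, 1 sulfur; one six-membered aromatic ring of carbon only), on a saturated chain carbon, three bonds along the chain from an amide-type nitrogen. For the measured compounds named here, no pair of measured compounds isolates this exchange, so its effect is unmeasured here. Going by the values given here, the only compound carrying the entering group, compound 2, gives the lower of the two numbers, but on a different core. On that thin basis, a step from compound 1 toward lower numbers is expected, of modest size, a 2.7-fold lower number from compound 1 to compound 3 (0.43 log units; beyond the scatter), though a result within the scatter of compound 1 would not surprise. Compound 3 is thus estimated at 6000 nM, with a range from 1500 nM to 20000 nM.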

Compound 3, half-maximal inhibitory concentration in the MCF7 assay: 7000 nM
Estimate against measurement, compound 3: 1.2-fold (0.07 log units) below, within the range that was stated.
By their numbers in the MCF7 assay, from the lowest: compound 2; then compound 3; then compound 1.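

In the MCF7 assay, the exchange of tellurium for sulfur in the phenyl-bearing group, on a saturated chain carbon, three bonds along the chain from an amide-type nitrogen, now has its first matched reading: a 2.3-fold lower number from compound 1 to compound 3 (0.36 log units; beyond the scatter). The same exchange also registers in a physicochemical assay for lipophilicity, read by HPLC, measured as octanol-water partition (on this read-out higher numbers stand for higher lipophilicity and lower numbers for lower lipophilicity), where compound 1 gives 4.2 and compound 3 gives 1.97, a large step set against the modest one in cytotoxicity. In this single pair, the tellurium compound therefore shows both stronger inhibition and lower measured lipophilicity: the measured partition coefficient of compound 1, 4.2, and of compound 3, 1.97, a number 2.23 log units lower (beyond the scatter).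

One pair does not separate any contribution of the lipophilicity shift to the lower number in the MCF7 assay from a contribution of the tellurium atom itself, and it does not show whether the step carries over to the core of compound 2. Also open, as far as these compounds go, is how the series would read with the selenium analogue of this group, which places selenium between the phenyl ring and the chain, or with a longer chain leading to the chalcogen atom.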